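The source may hold more compounds than are shown below. What is called first, only, known or untested is meant among the compounds shown, and "the series" means these compounds.

In a functional assay on the whole organism with Rattus norvegicus as the target (a lower number here means that less compound is needed, a higher number that more compound is needed for the effect), compound 3 `CC(C#CC[N+](C)(C)C)OC(=O)Nc1ccc(Cl)cc1` gives 0.029 umol/kg and stands within the scatter of compound 2 `C[C@H](C#CC[N+](C)(C)C)OC(=O)Nc1ccc(Cl)cc1` at 0.039 umol/kg in that read-out. Compound 1 `C[C@@H](C#CC[N+](C)(C)C)OC(=O)Nc1cccc(Cl)c1` at 0.12 umol/kg needs clearly more than compound 3 does. Compound 4 `C[C@@H](C#CC[N+](C)(C)C)OC(=O)Nc1ccc(Cl)cc1` differs from compound 3 as follows: the two compounds have the same atoms and bonds; at least one stereo element is drawn with a configuration in one of them and without one in the other: 1 of 1 stereo elements differ; a stereocentre at a saturated chain carbon is drawn without a configuration in compound 3 and S in compound 4 and so a stereocentre at a saturated chain carbon, drawn without a configuration in compound 3, is drawn S in compound 4. Among the compounds with values here, only one measured step bears on this centre. It is a 1.3-fold lower number from compound 2 to compound 3 (0.13 log units; within the scatter) where the same centre, drawn R in compound 2, loses its drawn configuration. That step is small, so no step beyond the scatter is expected in this assay for compound 4, with at most a slight lean towards a lower number. The estimated step is a 1.2-fold lower number from compound 3 to compound 4 (0.08 log units; within the scatter) and no larger one is expected. For compound 4 the expected value is 0.024 umol/kg with an estimated range from 0.009 umol/kg to 0.07 umol/kg in this assay when it is measured.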

Compound 4, dose for half-maximal effect: 0.008 umol/kg
The estimate for compound 4 lay 3.0-fold (0.48 log units) above the measured number; measured number outside the range, below it.
By their numbers in this assay, from the lowest: compound 4; then compounds 3 and 2 (each within the scatter of the next); then compound 1.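

In this assay, the earlier step, a 1.3-fold lower number from compound 2 to compound 3 (0.13 log units; within the scatter), gave no sign that this stereocentre mattered, but drawing it S brings a clear change, with a 3.6-fold lower number from compound 3 to compound 4 (0.56 log units; beyond the scatter) and a 4.9-fold lower number from compound 2 to compound 4 (0.69 log units; beyond the scatter). The saturated chain carbon is therefore a position where configuration counts in this assay, and among these para-free comparisons of the shared core the S form needs less compound than the R form. The larger step can be assigned to configuration alone because of this fact: the fact that compounds 2 and 4 differ only in the configuration as drawn.

The compounds shown leave open whether the same preference for S holds with the chlorine placed as in compound 1. They also leave open whether it persists with an ethyl group at this centre or with a fluorine in place of the chlorine.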